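A few compounds are considered here, and "the series" means these few. Any claim that something is new, unique, unknown or untested is made for them only; others in the source may bear on it.

In a functional assay on A-375 cells (Homo sapiens) for inhibition, read by MTT assay, with a stated time of 4 days (a lower number here means a stronger inhibitor, a higher number a weaker inhibitor), compound 1 `CN1C[C@@H]2C[C@H]1CN2c1cccc(-c2ccnc3c(-c4cccc5[nH]ncc45)c(-c4ccncc4)nn23)c1` gives 1400 nM, compound 2 `CCN1C[C@@H]2C[C@H]1CN2c1cc(F)c(-c2ccnc3c(-c4cccc5[nH]ncc45)c(-c4ccncc4)nn23)c(F)c1` gives 56 nM and compound 3 `CC(C)N1C[C@@H]2C[C@H]1CN2c1cc(F)c(-c2ccnc3c(-c4cccc5[nH]ncc45)c(-c4ccncc4)nn23)c(F)c1` gives 55 nM. Compound 3 therefore sits level with compound 2, within the scatter, and well under compound 1.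

Compound 4 `Fc1cc(N2C[C@@H]3C[C@H]2CN3C2CCC2)cc(F)c1-c1ccnc2c(-c3cccc4[nH]ncc34)c(-c3ccncc3)nn12` carries cyclobutyl in place of isopropyl on an amine nitrogen in a ring.

Among the measured compounds shown here, the one measured step in this substituent, a 1.0-fold lower number from compound 2 to compound 3 (0.01 log units; within the scatter), lies within the scatter. For the measured compounds named here, it is a smaller change than this one, and no measured step shows the effect of a ring here. A step beyond the scatter is therefore not expected in this assay. The estimated change is a 1.1-fold lower number from compound 3 to compound 4 (0.04 log units; within the scatter). Compound 4 is expected at 50 nM, with an estimated range of 22 nM to 115 nM.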

Compound 4, half-maximal inhibitory concentration: 78 nM
Estimate against measurement, compound 4: 1.6-fold (0.19 log units) below, and the stated range covers the measured number.
By their numbers in this assay, from the lowest: compounds 3, 2 and 4 (each within the scatter of the next); then compound 1.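

In this assay, the step with cyclobutyl is a 1.4-fold higher number from compound 3 to compound 4 (0.15 log units; within the scatter) and the step from the smaller group is a 1.4-fold higher number from compound 2 to compound 4 (0.14 log units; within the scatter), so both lie within the scatter. Ethyl, isopropyl and cyclobutyl on this amine nitrogen therefore stand level, and this first ring at the position, a four-membered non-aromatic ring of carbon only, leaves the number as the open chains do. No measurement available gives a reason for this level reading.

Open, going by these compounds, is whether a longer chain such as n-butyl, a larger ring such as cyclohexyl, or an oxetane ring holds the number at this level.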